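The source may report more compounds than this note shows. Statements on the series, on what has been measured and on what is new or still open speak of the compounds shown alone.

Compound 1, with the structure `CNC[C@]1(O)Cc2ccccc2[C@@H]1Oc1ccccc1CO`, carries a hydroxymethyl on the aryl ether of the shared core. In an in vitro assay on HEK293 cells for inhibition of sodium-dependent dopamine transporter (Homo sapiens) (a lower number here means a stronger inhibitor, a higher number a weaker inhibitor), compound 1 gives only a limit, > 10000 nM, and no number. Its companion compound 2, with the structure `CNC[C@]1(O)Cc2ccccc2[C@@H]1Oc1c(C)cccc1F`, is measured in this assay too. In this assay compound 2 likewise reaches only the limit of > 10000 nM. Among the measured compounds shown here, both values therefore sit at the same edge, which is the situation summarised by the limit of > 10000 nM in this assay, at which 2 of the 2 values shown sit: neither compound gives a number, so no step between measured compounds can be counted, and where compound 1 truly stands is unknown beyond that limit.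

Compound 3, with the structure `CNC[C@]1(O)Cc2ccccc2[C@@H]1Oc1ccccc1-c1cccc2ccccc12`, is not yet measured in this assay. It differs from compound 1 by naphthalen-1-yl in place of hydroxymethyl on an aromatic carbon. For the measured compounds named here, with no measured step to lean on, the size and direction of this change can only be guessed. The step from compound 1 to compound 3 is expected to be an at least 3.3-fold lower number from compound 1 to compound 3 (0.52 log units; beyond the scatter), with the measured value of compound 1 itself only a limit. Compound 3 is thus estimated at 3000 nM, within a range of 500 nM to 20000 nM.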

Compound 3, half-maximal inhibitory concentration: 10000 nM
For compound 3 the middle estimate is 3.3-fold (0.52 log units) below the measured one; low and high end bracket the measured number.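

In this assay compound 3 is the only compound shown that gives a number rather than a limit, so naphthalen-1-yl on this aromatic carbon, ortho to a large group, yields the first readable value in the series, though that value remains high at 10000 nM. Compound 1 gives > 10000 nM, which is a limit. Replacing hydroxymethyl with naphthalen-1-yl therefore gives a number no higher from compound 1 to compound 3 (the limit leaves the size open), and the size of this step cannot be read, because the other compounds sit at the edge of the assay: the limit of > 10000 nM in this assay, at which 2 of the 3 values shown sit.

The compounds shown leave open whether the result comes from the two aromatic rings entering or from the hydroxymethyl leaving, since both happen in the same change. They also leave open how this position would respond to a single phenyl ring, a methoxy group, an amine or a carboxylic acid on the same aromatic carbon, and whether any of these would give a clearly lower number in this assay.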